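This account rests on a few compounds, and the source may have more. Where it says the series, first, only, none or still open, it means among the compounds named here.

In an ADME assay on HEK293 cells (Homo sapiens) for cytotoxicity, read by MTT assay, with a stated time of 48 h (on this read-out lower numbers stand for stronger inhibition and higher numbers for weaker inhibition), compound 3 `CN(C)CCn1c(N)c(-c2nc3ccccc3n2C)c2nc(C#N)c(C#N)nc21` gives > 50000 nM, which is a limit of the assay and not a number. That places compound 3 at the limit of > 50000 nM in this assay, at which 1 of the 3 values shown sits. The related compounds carry numbers: compound 1 `CN(C)CCn1c(N)c(-c2nc3ccccc3[nH]2)c2nc(C#N)c(C#N)nc21` gives 9730 nM, and compound 2 `CN(C)CCCn1c(N)c(-c2nc3ccccc3[nH]2)c2nc(C#N)c(C#N)nc21` gives 8360 nM.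

Compound 4 `CN(C)CCCn1c(N)c(-c2nc3ccccc3n2C)c2nc(C#N)c(C#N)nc21` differs from compound 3 on a saturated chain carbon, two bonds along the chain from an aromatic nitrogen: (dimethylamino)methyl in place of dimethylamino on a saturated chain carbon, two bonds along the chain from an aromatic nitrogen. In words, (dimethylamino)methyl stands in place of dimethylamino, which turns a 2-(dimethylamino)ethyl chain into a 3-(dimethylamino)propyl chain.

Among the measured compounds shown here, two measured steps bear on this. The same chain change, made without the methyl on the aromatic nitrogen, gave a 1.2-fold lower number from compound 1 to compound 2 (0.07 log units; within the scatter). Adding that methyl, which compound 3 and compound 4 share, gave an at least 5.1-fold higher number from compound 1 to compound 3 (0.71 log units; beyond the scatter); this step sets the level of the pair and not the size of the chain change. On the strength of a 1.2-fold lower number from compound 1 to compound 2 (0.07 log units; within the scatter), no step beyond the scatter is expected for compound 4 in this assay, and the assay may again report only a limit. The expected step is a number no higher from compound 3 to compound 4 (the limit leaves the size open). Compound 4 is estimated at 50000 nM, with an expected range of 25000 nM to 100000 nM.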

Compound 4, half-maximal inhibitory concentration: 8410 nM
The estimate for compound 4 lay 5.9-fold (0.77 log units) above the measured number; the whole stated range lies above it.
By their numbers in this assay, from the lowest: compounds 2, 4 and 1 (each within the scatter of the next). At a limit, above all of these: compound 3.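

In this assay, the change from a 2-(dimethylamino)ethyl to a 3-(dimethylamino)propyl chain is no longer without effect once the aromatic nitrogen carries methyl, with an at least 5.9-fold lower number from compound 3 to compound 4 (0.77 log units; beyond the scatter), so the size of this change differs with the core that carries it: the same change on two cores in this assay, a 1.2-fold lower number (0.07 log units; within the scatter) from compound 1 to compound 2 and an at least 5.9-fold lower number (0.77 log units; beyond the scatter) from compound 3 to compound 4, at least 5.1-fold (0.70 log units) apart, beyond the scatter of two such steps. Read the other way, methyl in place of hydrogen on the aromatic nitrogen gives a 1.0-fold higher number from compound 2 to compound 4 (0.00 log units; within the scatter) on the 3-(dimethylamino)propyl chain, so the step beyond the scatter seen with the 2-(dimethylamino)ethyl chain does not carry over: the same change on two cores in this assay, an at least 5.1-fold higher number (0.71 log units; beyond the scatter) from compound 1 to compound 3 and a 1.0-fold higher number (0.00 log units; within the scatter) from compound 2 to compound 4, at least 5.1-fold (0.70 log units) apart, beyond the scatter of two such steps. The two changes therefore do not act independently in these four compounds, and only compound 3, which pairs methyl on the aromatic nitrogen with the 2-(dimethylamino)ethyl chain, gives a limit of the assay and not a number.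

On these data alone, the true size of the step from compound 3 to compound 4 stays open, as compound 3 gives only a limit. Also open, as far as these compounds go, is whether a longer chain ending in dimethylamino, or ethyl in place of methyl on the aromatic nitrogen, would read like compound 4 or like compound 3.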